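Trimming isopropoxy to ethoxy on the outer phenyl ring

A few compounds are considered here, and "the series" means these few. Any claim that something is new, unique, unknown or untested is made for them only; others in the source may bear on it.

Three compounds have so far been measured in a functional assay for agonist activity at G protein-coupled receptor 88 (Homo sapiens), read by HTRF and cAMP accumulation; on this read-out higher numbers stand for an effect only at larger amounts of compound and lower numbers for an effect already at smaller amounts:

- compound 1, `CC[C@H](C)[C@H](N)CN(C(=O)[C@@H]1C[C@H]1c1ccccc1)c1ccc(-c2ccccc2)cc1`, gives 230 nM; 800 nM (2 entries)
- compound 2, `CCc1ccc(-c2ccc(N(C[C@@H](N)[C@@H](C)CC)C(=O)[C@@H]3C[C@H]3c3ccccc3)cc2)cc1`, gives 44 nM
- compound 3, `CC[C@H](C)[C@H](N)CN(C(=O)[C@@H]1C[C@H]1c1ccccc1)c1ccc(-c2ccc(OC(C)C)cc2)cc1`, gives 72 nM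

Compound 3 and compound 2 share the same core and differ only in the group on the outer phenyl ring; the step of a 1.6-fold higher number from compound 2 to compound 3 (0.21 log units; within the scatter) is within the scatter, so the two numbers cannot be told apart. Compound 1, which carries no group on that ring, has two entries rather than one number, and those entries themselves show how far repeats of this assay can fall apart (the several entries of compound 1 in this assay, 230 nM; 800 nM (2 entries)).

Compound 4, `CCOc1ccc(-c2ccc(N(C[C@@H](N)[C@@H](C)CC)C(=O)[C@@H]3C[C@H]3c3ccccc3)cc2)cc1`, is not yet measured. It differs from compound 3 by hydrogen in place of methyl on a saturated chain carbon bound to an oxygen on an aromatic ring and a saturated chain carbon. For the measured compounds named here, this is a smaller change than the one from compound 2 to compound 3, which already stayed within the scatter. Going by the values given here, no other measured step touches this group. The expectation for compound 4 in this assay is therefore a step of a 1.2-fold lower number from compound 3 to compound 4 (0.08 log units; within the scatter), with no direction claimed beyond the scatter. The estimated value of compound 4 is 60 nM, expected to fall between 25 nM and 150 nM.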

Compound 4, half-maximal effective concentration: 90 nM
Compound 4: the middle estimate sits 1.5-fold (0.18 log units) below what was measured; measured number inside the range.
By their numbers in this assay, from the lowest: compounds 2, 3 and 4 (each within the scatter of the next, the first and the last beyond it).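

Shortening isopropoxy to ethoxy on the outer phenyl ring loses one methyl, yet this assay cannot separate the two ethers (see a 1.3-fold higher number from compound 3 to compound 4 (0.10 log units; within the scatter)), so this part of the group can change in size by that much without a readable change in the number. For the compounds shown here, compound 4 also gives the first measured step at this position that lies beyond the scatter, for ethoxy in place of ethyl (see a 2.0-fold higher number from compound 2 to compound 4 (0.31 log units; beyond the scatter)), although the larger isopropoxy group stayed within the scatter of ethyl (see a 1.6-fold higher number from compound 2 to compound 3 (0.21 log units; within the scatter)). That makes any reading of ether against ethyl uncertain, as the step is modest and repeats in this assay can lie far apart: (the several entries of compound 1 in this assay, 230 nM; 800 nM (2 entries)).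

The compounds shown cover only ethyl, ethoxy and isopropoxy on a substituted outer ring, so it remains open whether a shorter methoxy group or a longer chain such as butoxy would stay in this range. Going by these compounds, it also remains open how an amine or a carboxylic acid on that ring would read in this assay when compared with these ethers.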